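Chloro added to the urea aryl of compound 3

This account rests on a few compounds, and the source may have more. Where it says the series, first, only, none or still open, it means among the compounds named here.

Series notes. Of the compounds shown here, three measured so far share one core: compound 1 `COc1cc(-c2nn(-c3cccc(NC(=O)c4ccc(Cl)c(C(F)(F)F)c4)c3)cc2-c2ccncc2)ccc1Cl`, compound 2 `COc1cc(-c2nn(-c3cccc(NC(=O)c4cccc(C(F)(F)F)c4)c3)cc2-c2ccncc2)ccc1Cl` and compound 3 `COc1cc(-c2nn(-c3cccc(NC(=O)Nc4cccc(C(F)(F)F)c4)c3)cc2-c2ccncc2)ccc1Cl`. In a functional assay on CAKI-1 cells (Homo sapiens) for inhibition, read by sulforhodamine B assay, with a stated time of 48 h (on this read-out higher numbers stand for weaker inhibition of growth and lower numbers for stronger inhibition of growth), compound 1 gives 2300 nM. Compound 2 gives 2010 nM, and compound 3 gives 1030 nM. Compound 3 carries the lowest of the three numbers; the moves to it were a 2.2-fold lower number from compound 1 to compound 3 (0.35 log units; beyond the scatter) and a 2.0-fold lower number from compound 2 to compound 3 (0.29 log units; within the scatter), so it is separated from compound 1 only, while compound 2 and compound 3 cannot be ordered.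

Compound 4 `COc1cc(-c2nn(-c3cccc(NC(=O)Nc4ccc(Cl)c(C(F)(F)F)c4)c3)cc2-c2ccncc2)ccc1Cl` is not yet measured. It differs from compound 3 by chloro in place of hydrogen on an aromatic carbon. Among the measured compounds shown here, the one step that bears on this change is the reverse exchange on the amide pair, a 1.1-fold lower number from compound 1 to compound 2 (0.06 log units; within the scatter), which left the number within the scatter. Nothing in the data therefore points to a move beyond the scatter here. The step of a 1.1-fold higher number from compound 3 to compound 4 (0.03 log units; within the scatter) is expected to stay within the scatter. Compound 4 in this assay is estimated at 1100 nM, with a range from 500 nM to 2500 nM.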

Compound 4, concentration for 50% growth inhibition: 992 nM
Estimate against measurement, compound 4: 1.1-fold (0.04 log units) above; the range from low to high includes it.
By their numbers in this assay, from the lowest: compounds 4, 3, 2 and 1 (each within the scatter of the next, the first and the last beyond it).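

In this assay, chloro on the aryl ring, ortho to the trifluoromethyl group, leaves the number within the scatter on the urea as well: a 1.0-fold lower number from compound 3 to compound 4 (0.02 log units; within the scatter). The same exchange therefore now reads as flat on both the amide and the urea linker: the same change on two cores in this assay, a 1.1-fold lower number (0.06 log units; within the scatter) from compound 1 to compound 2 and a 1.0-fold higher number (0.02 log units; within the scatter) from compound 4 to compound 3, 1.2-fold (0.07 log units) apart, within the scatter of two such steps With the chloro present, the urea compound 4 is separated from both amides, though only modestly: a 2.0-fold lower number from compound 2 to compound 4 (0.31 log units; beyond the scatter) and a 2.3-fold lower number from compound 1 to compound 4 (0.37 log units; beyond the scatter). Compound 3 had been separated from compound 1 only.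

Only hydrogen and chloro are shown at this position, so it remains open whether a larger or charged group there, such as a methoxy group, an amine or a carboxylic acid, would move the number beyond the scatter. The flat response is also shown only in this one cell assay.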